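Swapping the pendant group on the saturated ring carbon

The compounds below may be only part of what the source reports. "The series", "measured", "known", "first", "only" and "open" are said of these compounds alone.

Compounds measured so far:
compound 1, `N#CC1=C(N)N(c2ccc(S(N)(=O)=O)cc2)C2=C(C(=O)CCC2)C1c1ccc(O)cc1`, 90%
compound 2, `N#CC1=C(N)N(c2ccc(S(N)(=O)=O)cc2)C2=C(C(=O)CCC2)C1/C=C/c1ccccc1`, 2%
compound 3, `N#CC1=C(N)N(c2ccc(S(N)(=O)=O)cc2)C2=C(C(=O)CCC2)C1c1c(O)ccc2ccccc12`, 0%

In a functional assay on Ehrlich cells (Mus musculus) for antiproliferative activity, read by trypan blue exclusion, with a stated time of 2 h, tested at 10 ug/mL (a higher number here means a stronger effect of the compound at the concentration tested, a lower number a weaker effect), compound 1 gives 90%, while compound 2 gives 2% and compound 3 gives 0%. Compound 2 thus stands far below compound 1, the gap being a number 88 percentage points lower from compound 1 to compound 2 (beyond the scatter), and level with compound 3, since a number 2 percentage points lower from compound 2 to compound 3 (within the scatter). Compound 4, `Cc1ccoc1C1C(C#N)=C(N)N(c2ccc(S(N)(=O)=O)cc2)C2=C1C(=O)CCC2`, differs from compound 2 by 3-methylfuran-2-yl in place of 2-phenylethenyl on a saturated ring carbon.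

Among the compounds with values here, the steps that bear on this change are a number 88 percentage points lower from compound 1 to compound 2 (beyond the scatter), a number 90 percentage points lower from compound 1 to compound 3 (beyond the scatter) and a number 2 percentage points lower from compound 2 to compound 3 (within the scatter). Two of three pendant groups tried gave near-zero readings; only the 4-hydroxyphenyl group gave a strong effect. Nothing shown tells whether 3-methylfuran-2-yl behaves like that group, so compound 4 is expected to stay low, with the step of a number 8 percentage points higher from compound 2 to compound 4 (within the scatter) most likely within the scatter. Compound 4 is therefore estimated at 10%, ranging from 0% to 55%.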

Compound 4, a percentage reported as activity, at one concentration (the size of the read-out at that concentration, not a potency): 2%
Beside the measured number, compound 4's estimate is 8 percentage points above it; low and high end bracket the measured number.
By their numbers in this assay, from the lowest: compounds 3, 2 and 4 (each within the scatter of the next); then compound 1.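

In this assay, the 3-methylfuran-2-yl group, a five-membered aromatic ring with one oxygen, reads level with the two other low groups, with no change at the digits printed from compound 2 to compound 4 (within the scatter) and a number 2 percentage points higher from compound 3 to compound 4 (within the scatter). It also lies far under the top reading, with a number 88 percentage points lower from compound 1 to compound 4 (beyond the scatter), so three of the four pendant groups on this saturated ring carbon now give near-zero readings, and compound 1 alone goes against that pattern. No supporting evidence accounts for this reading. What the compounds shown leave open is whether a plain phenyl or a 4-methoxyphenyl group on this carbon would keep the strong effect of the 4-hydroxyphenyl group.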